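Pentafluorophenyl for phenyl on the oxime ether of compound 1

The source may hold more compounds than are shown below. What is called first, only, known or untested is meant among the compounds shown, and "the series" means these compounds.

Working notes on a small set of oxime ethers measured in an assay on HepG2 cells for agonist activity at nuclear receptor subfamily 1 group I member 3 (Homo sapiens), read by a luciferase reporter, with a stated time of 23 h; on this read-out lower numbers stand for an effect already at smaller amounts and higher numbers for an effect only at larger amounts of compound. Compound 1 `C(=N/OCc1ccccc1)\c1c(-c2ccc3ccccc3c2)nc2occn12` gives 840 nM in this assay. Compound 2 `CC(C)c1ccc(-c2nc3sccn3c2/C=N/OCc2ccc(Cl)c(Cl)c2)cc1`, which carries a different core and a 3,4-dichlorobenzyl group on the same kind of oxime ether, gives 590 nM. Of the two numbers available, compound 1 has the higher one, but the two values lie within the usual scatter of each other, so nothing can be read from their order.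

The next compound, compound 3 `Fc1c(F)c(F)c(CO/N=C/c2c(-c3ccc4ccccc4c3)nc3occn23)c(F)c1F`, keeps the core of compound 1 and changes only the benzyl part: 2,3,4,5,6-pentafluorophenyl in place of phenyl on a saturated chain carbon bound to an oxygen. Within the data shown here, no measured pair shows this change, so there is no step to draw on. Compound 2 shows that a halogenated benzyl group can sit on this type of oxime ether without loss, but its core differs, so it does not fix a direction. The expectation for the step from compound 1 to compound 3 in this assay is a 1.3-fold lower number from compound 1 to compound 3 (0.11 log units; within the scatter), a change not clearly beyond the scatter. Compound 3 is estimated at 650 nM, within a range of 200 nM to 2200 nM.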

Compound 3, half-maximal effective concentration: 1700 nM
For compound 3 the middle estimate is 2.6-fold (0.42 log units) below the measured one; measured number inside the range.
By their numbers in this assay, from the lowest: compounds 2 and 1 (each within the scatter of the next); then compound 3.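

In this assay, 2,3,4,5,6-pentafluorophenyl in place of phenyl on a saturated chain carbon bound to an oxygen gives a 2.0-fold higher number from compound 1 to compound 3 (0.31 log units; beyond the scatter) in a pair that differs in this one place only. Among these compounds, the step is modest, but it is the first reading of a direction at this position, which compound 2 could not supply since it differs from compound 1 in more than one place; here the full replacement of the ring hydrogens by fluorine moves the series toward an effect only at larger amounts of compound, so this position is not indifferent to the change. Nothing measured here accounts for the step.

The pair leaves open whether the shift belongs to the full set of fluorines or would also appear with a single fluorine on the phenyl ring, and how a methoxy group or an amine on that ring would read. Also open, as far as these compounds go, is whether the same replacement moves the number in the same direction on the core of compound 2, where the benzyl group carries chlorine instead.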